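The source may report more compounds than this note shows. Statements on the series, on what has been measured and on what is new or still open speak of the compounds shown alone.

Measured in a functional assay on HCT-116 cells (Homo sapiens) for inhibition, read by luminescence and resazurin assay, with a stated time of 3 days; a higher number here means a weaker inhibitor, a lower number a stronger inhibitor:
- Compound 1 `CCNc1ncc(C)c(NCc2ccc(NC(=O)c3ccc(F)cc3)cc2)n1`: > 20000 nM, a limit.
- Compound 2 `CNc1ncc(C)c(NCc2ccc(NC(=O)c3ccc(F)cc3)cc2)n1`: > 20000 nM, a limit.
- Compound 3 `C=CCNc1nc(NCc2ccc(C(=O)Nc3ccc(F)cc3)cc2)c2ccccc2n1`: 14000 nM.

Compound 2 has no number in this assay, only a limit, and it sits at the limit of > 20000 nM in this assay, at which 2 of the 3 values shown sit. Within the data shown here, the one measured step touching it is a step that the two limits leave unreadable from compound 1 to compound 2, which gives no size to carry forward. Compound 4 `CNc1ncc(Br)c(NCc2ccc(NC(=O)c3ccc(F)cc3)cc2)n1` changes compound 2 in one place: bromo in place of methyl on an aromatic carbon. This puts bromo in place of methyl on an aromatic carbon. Among the measured compounds shown here, no measured step covers that change, so no step beyond the scatter is expected in this assay, and another limit is the likeliest report. The expected change is a number no higher from compound 2 to compound 4 (the limit leaves the size open). Compound 4 is estimated at 20000 nM, with an expected range of 8000 nM to 40000 nM.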

Compound 4, half-maximal inhibitory concentration: > 20000 nM
Compound 4 was reported as a limit (the forecaster's own chance of this, stated with the estimate: 65%); the middle value sits exactly at the limit.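

Among these compounds, compound 2 and compound 4 are both reported only as limits, so no step between them can be read: the limit of > 20000 nM in this assay, at which 3 of the 4 values shown sit.

The compounds shown leave open whether bromo in place of methyl changes inhibition at all, and by how much.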